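A few compounds are considered here, and "the series" means these few. Any claim that something is new, unique, unknown or untested is made for them only; others in the source may bear on it.

Of the compounds shown here, two have been measured in a functional assay on the whole organism (strain albino) for inhibition, with Rattus norvegicus as the target, read by paw edema, with stated times of 30 min and 1 h, at a dose of 0.28 mmol/kg by the oral route; on this read-out lower numbers stand for less inhibition and higher numbers for more inhibition at the one dose given (going by the name of the read-out). Compound 1 `C=CCn1c(SCC(=O)Nc2ccc(C(C)=O)cc2)nnc1-c1ccccc1` carries an allyl chain on the aromatic nitrogen of the shared core and, in this assay, compound 1 gives 48%. Compound 2 `CCn1c(SCC(=O)Nc2ccc(C(C)=O)cc2)nnc1-c1ccc(OC)c(OC)c1` carries an ethyl chain there and two methoxy groups on its aryl ring; in this assay compound 2 gives 56%. Compound 2 thus stands at the top of the two numbers seen so far, but its gap to compound 1 lies within the scatter of repeated measurements, so the two results cannot be told apart.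

Compound 3 `C=CCn1c(SCC(=O)Nc2ccc(C(C)=O)cc2)nnc1-c1ccc(OC)c(OC)c1` has not been measured. It keeps the methoxy groups of compound 2 and differs from it in one place: vinyl in place of methyl on a saturated chain carbon bound to an aromatic nitrogen. Compounds 1 and 2, which differ in this same chain as well as elsewhere, give numbers within the scatter of each other, so no step beyond the scatter is expected here either. For compound 3 the estimated step from compound 2 is a number 2 percentage points lower from compound 2 to compound 3 (within the scatter). Compound 3 is therefore expected to give about 54%, within a range from 40% to 68%.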

Compound 3, a percentage reported as inhibition, in the whole organism at one dose (the size of the read-out at that dose, not a potency): 56%
Compound 3: the middle estimate sits 2 percentage points below what was measured; the range from low to high includes it.
By their numbers in this assay, from the lowest: compounds 1, 2 and 3 (each within the scatter of the next).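

In this assay, vinyl in place of methyl on a saturated chain carbon bound to an aromatic nitrogen, the same change as ethyl to allyl, gives no change at the digits printed from compound 2 to compound 3 (within the scatter) with the rest of the molecule held fixed. Among the compounds shown here, this is the first time the chain can be read alone, and with the two methoxy groups present, ethyl and allyl cannot be told apart at this position. The aryl group can now also be read alone, since 3,4-dimethoxyphenyl in place of phenyl on an aromatic carbon, with the allyl chain kept, gives a number 8 percentage points higher from compound 1 to compound 3 (within the scatter) and so also shows no change that can be told from the scatter; no supporting data are available to explain either result.

Still open, going by these compounds, is whether a longer chain such as butyl, or a chain ending in an amine, at the same nitrogen would shift the read-out beyond the scatter. The compounds shown also leave open how a single methoxy group or a carboxylic acid on the aryl ring would compare with the 3,4-dimethoxyphenyl and phenyl groups.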